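Methyl for Methoxy on the Hydrazone Aryl Ring

This account rests on a few compounds, and the source may have more. Where it says the series, first, only, none or still open, it means among the compounds named here.

Three related hydrazones were tested in an ADME assay on NIH3T3 cells (Mus musculus) for cytotoxicity, read by XTT assay, with a stated time of 24 h; on this read-out higher numbers stand for weaker inhibition and lower numbers for stronger inhibition. Compound 1 `Cc1ccc(/C=N/NC(=O)CSc2nnnn2C)cc1` gives 3160000 nM in this assay. In this assay compound 2 `COc1ccc(/C=N/NC(=O)CSc2nnnn2C)cc1` gives only the limit > 10000000 nM, which is not a number. Compound 3 `COc1cccc(/C=N/NC(=O)CSc2nnnn2C)c1` gives 600000 nM in this assay, the lowest of the two numbers. Compound 3 and compound 2 hold the same atoms joined differently; the difference between the two cores is not broken down here. The change methyl in place of methoxy on an aromatic carbon produced an at least 3.1-fold lower number from compound 2 to compound 1 (0.50 log units; beyond the scatter); its size is only a lower bound because the limit of > 10000000 nM in this assay, at which 1 of the 3 values shown sits, is all that is known of compound 2. Compound 4 `Cc1cccc(/C=N/NC(=O)CSc2nnnn2C)c1` carries the same kind of change, (methyl in place of methoxy on an aromatic carbon), now meta rather than para to the large group. Resting on an at least 3.1-fold lower number from compound 2 to compound 1 (0.50 log units; beyond the scatter), the expected step is a 2.4-fold lower number from compound 3 to compound 4 (0.38 log units; beyond the scatter) in this assay. Compound 4 is therefore estimated at 250000 nM, between 60000 nM and 1000000 nM.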

Compound 4, half-maximal inhibitory concentration: 6250000 nM
Estimate against measurement, compound 4: 25-fold (1.40 log units) below; measured number outside the range, above it.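

On the core of compound 3, methyl in place of methoxy gave a 10-fold higher number from compound 3 to compound 4 (1.02 log units; beyond the scatter) in this assay, the opposite direction to the step seen on the core of compound 1. The change therefore cannot be carried from one core to the other in this series as a fixed shift: the same change on two cores in this assay, an at least 3.1-fold lower number (0.50 log units; beyond the scatter) from compound 2 to compound 1 and a 10-fold higher number (1.02 log units; beyond the scatter) from compound 3 to compound 4, at least 32-fold (1.51 log units) apart, beyond the scatter of two such steps This does not show why the two cores part, and the earlier step is only a lower bound, since compound 2 is known only as a limit: the limit of > 10000000 nM in this assay, at which 1 of the 4 values shown sits.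

The compounds shown leave open how an amine or a carboxylic acid on the same aromatic carbon would read in this assay. They also leave open whether a longer chain, such as ethoxy, would follow methoxy or methyl on either core.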